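A few compounds are considered here, and "the series" means these few. Any claim that something is new, unique, unknown or untested is made for them only; others in the source may bear on it.

Working notes on the series: in an ADME assay on K562 cells (Homo sapiens) for cytotoxicity, with a stated time of 72 h (on this read-out lower numbers stand for stronger inhibition and higher numbers for weaker inhibition), compound 1 (`COc1ccccc1CNc1ncnc2c1ncn2C1CCCCO1`) gives 97000 nM. Compound 2 (`Oc1cccc(CNc2ncnc3c2ncn3C2CCCO2)c1`) is reported only as a limit, > 100000 nM. Compound 3 (`COc1ccccc1CNc1ncnc2c1ncn2C1CCCO1`) has 2-methoxyphenyl in place of 3-hydroxyphenyl on a saturated chain carbon bound to a nitrogen on an aromatic ring. No measured step sizes this change. In this assay, little or no shift is expected, if anything towards stronger inhibition, since compound 1, which also carries 2-methoxyphenyl, gives 97000 nM. The expected change is an at least 1.1-fold lower number from compound 2 to compound 3 (0.04 log units; that floor lies within the scatter). The estimate for compound 3 is 90000 nM, with an expected range of 40000 nM to 150000 nM.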

Compound 3, half-maximal inhibitory concentration: > 100000 nM
Compound 3 was reported as a limit (the forecaster's own chance of this, stated with the estimate: 50%); middle value at least 1.1-fold (0.04 log units) away from the limit.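

In this assay compound 3 is reported only as a limit, > 100000 nM. Oxolan-2-yl in place of oxan-2-yl on an aromatic nitrogen gives an at least 1.0-fold higher number from compound 1 to compound 3 (0.01 log units; that floor lies within the scatter). The step from 3-hydroxyphenyl to 2-methoxyphenyl cannot be read, because both values are limits: the limit of > 100000 nM in this assay, at which 2 of the 3 values shown sit.

Open, as far as these compounds go, is how far compound 2 and compound 3 actually lie beyond the limit of this assay. Also open, from the compounds shown here alone, is whether an amine or a carboxylic acid on the phenyl ring would give a value that can be read in this assay.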